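Aryl changes on the shared core: toxicity working notes

The source may hold more compounds than are shown below. What is called first, only, known or untested is meant among the compounds shown, and "the series" means these compounds.

Values in a toxicity assay on THP-1 cells (Homo sapiens) for inhibition; a higher number here means that more compound is tolerated, a lower number that less compound is tolerated:
- compound 1 `Cn1c(-c2ccc(Br)cc2)cnc1NC(=O)c1ccc(F)cc1`: 46000 nM
- compound 2 `COc1cccc(-c2cnc(NC(=O)c3ccc(F)cc3)n2C)c1`: > 100000 nM (a limit of the assay, not a number)

Compound 2 stands only at a limit in this assay. Compound 3 `Cc1ccc(-c2cnc(NC(=O)c3ccc(F)cc3)n2C)cc1` differs from compound 2 by 4-methylphenyl in place of 3-methoxyphenyl on an aromatic carbon, with 4-methylphenyl in place of 3-methoxyphenyl on an aromatic carbon. For the measured compounds named here, the one measured step bearing on this is an at least 2.1-fold higher number from compound 1 to compound 2 (0.33 log units; beyond the scatter). Read backwards, that step has a 4-substituted group replacing 3-methoxyphenyl, so a lower number of modest size is expected in this assay, toward compound 1 with 46000 nM. The estimated step is an at least 1.6-fold lower number from compound 2 to compound 3 (0.22 log units; that floor lies within the scatter). For compound 3 the expected value is 60000 nM, with an estimated range of 25000 nM to 130000 nM.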

Compound 3, half-maximal cytotoxic concentration: 60000 nM
For compound 3 middle estimate and measured number coincide at the digits printed, within the range that was stated.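

In this assay, replacing bromo with methyl on the phenyl gives a 1.3-fold higher number from compound 1 to compound 3 (0.12 log units; within the scatter), so these two 4-substituted phenyl groups are not separated at this position. The change from 3-methoxyphenyl to 4-methylphenyl gives an at least 1.6-fold lower number from compound 2 to compound 3 (0.22 log units; that floor lies within the scatter), so a difference between these two groups is not established. Compound 2 stands at a limit of the assay, not a number: the limit of > 100000 nM in this assay, at which 1 of the 3 values shown sits.

On these data alone, whether the methoxy group or its placement sets compound 2 apart from compound 1 remains open. So does how a phenyl bearing an amine or a carboxylic acid would read in this assay.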